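A halogen swap between two compounds at the assay limit

This account rests on a few compounds, and the source may have more. Where it says the series, first, only, none or still open, it means among the compounds named here.

Compound 1, `Cc1ccc(S/C(=C/c2c(O)cc(O)cc2O)C(=O)c2ccc(Cl)cc2)cc1`: in a functional assay on DU-145 cells (Homo sapiens) for inhibition, read by trypan blue exclusion, with a stated time of 96 h (on this read-out lower numbers stand for stronger inhibition of growth and higher numbers for weaker inhibition of growth), compound 1 gives > 100000 nM, which is a limit of the assay rather than a number.
Compound 2, `Cc1ccc(S(=O)(=O)/C(=C/c2c(O)cc(O)cc2O)C(=O)c2ccc(Br)cc2)cc1`: in this assay compound 2 gives > 100000 nM, likewise only a limit.

Compound 2 thus stands where the other value also stands, since (the limit of > 100000 nM in this assay, at which 2 of the 2 values shown sit). Compound 3, `Cc1ccc(S(=O)(=O)/C(=C/c2c(O)cc(O)cc2O)C(=O)c2ccc(Cl)cc2)cc1`, differs from compound 2 by chloro in place of bromo on an aromatic carbon. Within the data shown here, no measured step between compounds exists here, so no shift beyond the scatter is expected in this assay. The expected step is a step that the limit leaves unreadable from compound 2 to compound 3. Compound 3 is expected to give 150000 nM, within 60000 nM to 400000 nM, most likely again only a limit.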

Compound 3, concentration for 50% growth inhibition: > 100000 nM
Compound 3 ended at the assay's limit (the forecaster's own chance of this, stated with the estimate: 85%); the middle value does not contradict the limit.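

Among these compounds, no step among compound 1, compound 2 and compound 3 can be read, as each gives only a limit in this assay: the limit of > 100000 nM in this assay, at which 3 of the 3 values shown sit. The compounds shown leave open whether chloro in place of bromo, or (4-methylphenyl)sulfonyl in place of (4-methylphenyl)sulfanyl, changes growth inhibition at all.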